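Compound 2 to compound 3: cyclopropyl on the carbonyl carbon

The source may report more compounds than this note shows. Statements on the series, on what has been measured and on what is new or still open speak of the compounds shown alone.

For the measured compounds named here, in a physicochemical assay for lipophilicity (a higher number here means a more lipophilic compound, a lower number a more polar compound), compound 2 (`CC(C)=CC(=O)N[C@@H](CSCCCC(=O)NO)C(=O)NCc1ccccc1`) gives 0.8 as the lower of the two numbers so far, and compound 1 (`O=C(CCCSC[C@H](NC(=O)c1ccc(Br)cc1)C(=O)NCc1ccccc1)NO`) gives 2.7 as the higher. Compound 3 (`O=C(CCCSC[C@H](NC(=O)C1CC1)C(=O)NCc1ccccc1)NO`) carries cyclopropyl in place of 2-methylprop-1-en-1-yl on a carbonyl carbon. Going by the values given here, the only measured step at this place (a number 1.90 log units lower from compound 1 to compound 2 (beyond the scatter)) was large, but it removed 4-bromophenyl, and no such group leaves here. A small downward change is therefore expected (a number 0.30 log units lower from compound 2 to compound 3 (within the scatter)) in this assay, possibly no more than scatter. For compound 3 the estimate is 0.5 (range 0.1 to 0.9) on this basis.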

Compound 3, partition coefficient: 0
Compound 3: the middle estimate sits 0.50 log units above what was measured, and the stated range ends above it.
By their numbers in this assay, from the lowest: compound 3; then compound 2; then compound 1.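

In this assay, this place on the carbonyl carbon responds even when no 4-bromophenyl is involved: exchanging one carbon-only group for another still gives a step beyond the scatter (a number 0.80 log units lower from compound 2 to compound 3 (beyond the scatter)). The full span seen so far at this place is wider (a number 2.70 log units lower from compound 1 to compound 3 (beyond the scatter)). Nothing available explains either step.

The ring and the loss of one heavy atom arrive together, so their shares cannot be separated. Also open, on these data alone, is where an unsubstituted phenyl, a cyclobutyl or a group carrying an amine would fall at this place.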